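Going from 1-methylpyrrolidin-2-yl to pyrrolidin-2-yl

The compounds below may be only part of what the source reports. "The series", "measured", "known", "first", "only" and "open" are said of these compounds alone.

In an in vivo ADME assay on the whole organism (strain Sprague-Dawley) for pharmacokinetics, with Rattus norvegicus as the target (a higher number here means that more of the compound sits outside the plasma, a lower number that more of the compound stays in the plasma), compound 3 (`CN1CCCC1c1ccc(N2CC[C@H](NS(=O)(=O)/C=C/c3ccc(Cl)s3)C2=O)c(F)c1`) gives 0.8 L/kg, the lowest of the three numbers and beyond the scatter of both others. Compound 1 (`CN(C)[C@H]1CCc2cc(N3CC[C@H](NS(=O)(=O)c4ccc5cc(Cl)ccc5c4)C3=O)ccc21`) gives 2 L/kg and compound 2 (`CNC1CCc2cc(N3CC[C@H](NS(=O)(=O)c4ccc5cc(Cl)ccc5c4)C3=O)ccc21`) gives 2.4 L/kg, two values within the scatter of each other. Compound 4 (`O=C1[C@@H](NS(=O)(=O)/C=C/c2ccc(Cl)s2)CCN1c1ccc(C2CCCN2)cc1F`) has hydrogen in place of methyl on an amine nitrogen in a ring, 1-methylpyrrolidin-2-yl to pyrrolidin-2-yl (hydrogen in place of methyl on an amine nitrogen in a ring). Among the compounds with values here, no measured step covers this change, so in this assay a small upward move or none beyond the scatter is expected. The estimated step of a 1.3-fold higher number from compound 3 to compound 4 (0.10 log units; within the scatter) stays within the scatter. Compound 4 is estimated at 1 L/kg, with an expected range of 0.5 L/kg to 2 L/kg.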

Compound 4, volume of distribution at steady state: 0.7 L/kg
Compound 4: the middle estimate sits 1.4-fold (0.15 log units) above what was measured, within the range that was stated.
By their numbers in this assay, from the lowest: compounds 4 and 3 (each within the scatter of the next); then compounds 1 and 2 (each within the scatter of the next).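

In this assay, within the data shown here, hydrogen in place of methyl on an amine nitrogen in a ring gives a 1.1-fold lower number from compound 3 to compound 4 (0.06 log units; within the scatter), the first reading of any single change at this position. For this pair, the read-out therefore does not depend on the methyl, and the nitrogen carries either group without a shift beyond the scatter. No measured property bears on this result. Going by these compounds, whether an ethyl or an acetyl group on this nitrogen would also leave the read-out within the scatter stays open. So does whether the same change reads alike on another core.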